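This account rests on a few compounds, and the source may have more. Where it says the series, first, only, none or still open, it means among the compounds named here.

Working notes on the series. Three compounds are in view: compound 1 (`COc1cc2nc(SCC(=O)Nc3cccc(Cl)c3)nc(Nc3c(Cl)cc(/C=C/C#N)cc3Cl)c2cc1OC`), compound 2 (`COc1cc2nc([S+]([O-])CC(=O)Nc3ccc(Cl)cc3)nc(Nc3c(Cl)cc(/C=C/C#N)cc3Cl)c2cc1OC`) and compound 3 (`COc1cc2nc([S+]([O-])CC(=O)Nc3cccc(C(F)(F)F)c3)nc(Nc3c(Cl)cc(/C=C/C#N)cc3Cl)c2cc1OC`). The read-out is an ADME assay on MT4 cells (Homo sapiens) for cytotoxicity, read by MTT assay, with a stated time of 5 days; on this read-out lower numbers stand for higher toxicity in this test and higher numbers for lower toxicity in this test. In this assay compound 1 gives > 208000 nM as a limit of the assay and not a number. In this assay, for the measured compounds named here, compound 2 gives 14400 nM as the only true number so far, which makes it the sole quantitative anchor for the next measurement.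

Compound 3 keeps the shared core of compound 2 and changes only the aryl group on an amide-type nitrogen, with 3-(trifluoromethyl)phenyl in place of 4-chlorophenyl. The counted change is 3-(trifluoromethyl)phenyl in place of 4-chlorophenyl on an amide-type nitrogen at that place.

Going by the values given here, no measured pair differs in one place only, so the data give no size for such a step. A small move is therefore expected, towards slightly higher toxicity in this test if there is any move at all, starting from compound 2 at 14400 nM in this assay. The expected change is a 1.2-fold lower number from compound 2 to compound 3 (0.08 log units; within the scatter) and is not expected to exceed the usual scatter. For compound 3 the estimate is 12000 nM with an expected range (4000 nM to 40000 nM).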

Compound 3, half-maximal cytotoxic concentration: 21800 nM
Compound 3: middle estimate off by 1.8-fold (0.26 log units), on the low side, within the range that was stated.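

For the compounds shown here, the swap of 4-chlorophenyl for 3-(trifluoromethyl)phenyl on the amide-type nitrogen now has a measured size in this assay, which the earlier compounds could not give: a 1.5-fold higher number from compound 2 to compound 3 (0.18 log units; within the scatter). For this one pair, then, replacing one substituted phenyl with the other does not separate the two compounds on this read-out, although a single step sets no trend for other aryl groups at this place. Compound 1 adds nothing to this reading, since it differs from the others in more than one place and its value is a limit of the assay and not a number: the limit of > 208000 nM in this assay, at which 1 of the 3 values shown sits.

On these data alone, it remains open whether a group of another kind on the amide-type nitrogen, such as a plain alkyl chain, or a phenyl carrying a carboxylic acid or an amine, would move the number beyond the scatter. The contribution of the oxygen on sulfur also cannot be read from these compounds, and it would take a pair differing at that place alone to give it a size.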